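This account rests on a few compounds, and the source may have more. Where it says the series, first, only, none or still open, it means among the compounds named here.

Of the compounds shown here, three built on one shared core have been tested in an assay for inhibition of MAP kinase-interacting serine/threonine-protein kinase 1 (Homo sapiens), read by luminescence and ADP-Glo, with a stated time of 2 h; a lower number here means a stronger inhibitor, a higher number a weaker inhibitor. Compound 1 `NC(=O)c1ccc(Cn2cc(-c3ccc4cn[nH]c4c3)ccc2=O)cc1` carries a carboxamide on its benzyl ring. In this assay compound 1 gives only a limit, > 2000 nM, and no number. Compound 1 therefore sits at the limit of > 2000 nM in this assay, at which 1 of the 3 values shown sits. Compound 2 `O=c1ccc(-c2ccc3cn[nH]c3c2)cn1Cc1ccccc1C(F)(F)F` carries a trifluoromethyl on the benzyl ring, and in this assay compound 2 gives 133 nM. Compound 3 `O=c1ccc(-c2ccc3cn[nH]c3c2)cn1Cc1cccc(C(F)(F)F)c1` carries the same trifluoromethyl on another carbon of that ring, and in this assay compound 3 gives 40 nM, the lowest of the two numbers; its gap to compound 2 lies beyond the usual scatter.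

Compound 4 `O=c1ccc(-c2ccc3cn[nH]c3c2)cn1Cc1ccccc1` is compound 3 with one change: hydrogen in place of trifluoromethyl on an aromatic carbon. No step of exactly this kind has been measured here, so the expectation rests on the numbers shown. The trifluoromethyl in compound 2 and compound 3 goes with numbers well inside the range of the assay, and losing it is expected to give a weaker inhibitor, with a step of a 3.8-fold higher number from compound 3 to compound 4 (0.57 log units; beyond the scatter). In this assay compound 4 is estimated at 150 nM, within a range from 50 nM to 500 nM.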

Compound 4, half-maximal inhibitory concentration: 315 nM
Beside the measured number, compound 4's estimate is 2.1-fold (0.32 log units) below it, within the range that was stated.
By their numbers in this assay, from the lowest: compound 3; then compound 2; then compound 4. At a limit, above all of these: compound 1.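

Compound 4, with hydrogen in place of any group on its benzyl ring, gives the shared core a baseline, and it shows that losing the trifluoromethyl weakens inhibition from either carbon: there is a 7.9-fold higher number from compound 3 to compound 4 (0.90 log units; beyond the scatter) and a 2.4-fold higher number from compound 2 to compound 4 (0.37 log units; beyond the scatter). The larger loss belongs to the carbon that holds the group in compound 3. The carboxamide falls on the other side of this baseline, with an at least 6.3-fold lower number from compound 1 to compound 4 (0.80 log units; beyond the scatter), so a group on this ring can go with weaker as well as stronger inhibition, and that comparison rests on a limit for compound 1, not a number: the limit of > 2000 nM in this assay, at which 1 of the 4 values shown sits.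

The compounds shown leave open whether a smaller group, such as a methyl or a chlorine on the same carbon, would match the trifluoromethyl. Going by these compounds, how an amine or a carboxylic acid would fare on this ring also remains open.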